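A Second Chloro on an Inactive Compound

The source may report more compounds than this note shows. Statements on the series, on what has been measured and on what is new or still open speak of the compounds shown alone.

Measured in a functional assay on K562 cells (Homo sapiens) for cytotoxicity, read by MTT assay, with a stated time of 24 h; a lower number here means a stronger inhibitor, a higher number a weaker inhibitor
Compound 1 `COc1cc(/C=C2\CN(C)C/C(=C\c3ccc(Cl)cc3)C2=O)cc(OC)c1OC` gives > 20000 nM
Compound 2 `CN1C/C(=C\c2ccc(F)cc2)C(=O)/C(=C/c2cccc([N+](=O)[O-])c2)C1` gives 11300 nM
Compound 3 `CN1C/C(=C\c2ccc(Cl)cc2)C(=O)/C(=C/c2cccc([N+](=O)[O-])c2)C1` gives > 20000 nM

For compound 3 the reading > 20000 nM is a limit and not a number. For compound 1 the reading > 20000 nM is also a limit and not a number. Compound 3 therefore sits at the limit of > 20000 nM in this assay, at which 2 of the 3 values shown sit, and has no exact place on the scale. Only compound 2 has a true number, 11300 nM in this assay.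

Compound 4 `CN1C/C(=C\c2cccc([N+](=O)[O-])c2)C(=O)/C(=C/c2ccc(Cl)c(Cl)c2)C1` differs from compound 3 by one change, chloro in place of hydrogen on an aromatic carbon, which turns 4-chlorophenyl into 3,4-dichlorophenyl.

For the measured compounds named here, one measured step bears on this, and only loosely, since it swaps one halogen for another instead of adding one. That step, chloro in place of fluoro on an aromatic carbon, reads an at least 1.7-fold higher number from compound 2 to compound 3 (0.24 log units; that floor lies within the scatter) and gives only a floor. With so little to go on, no step beyond the scatter is expected in this assay, and another limit reading is quite likely. The expected change is a number no higher from compound 3 to compound 4 (the limit leaves the size open) on this estimate. For compound 4 the estimated value is 20000 nM with an expected range from 8000 nM to 45000 nM as its likely span.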

Compound 4, half-maximal inhibitory concentration: 15500 nM
The estimate for compound 4 lay 1.3-fold (0.11 log units) above the measured number, and the stated range covers the measured number.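

A second chloro on the ring, which turns 4-chlorophenyl into 3,4-dichlorophenyl, gives this position a true number in this assay, and the comparison reads as an at least 1.2-fold lower number from compound 3 to compound 4 (0.11 log units; that floor lies within the scatter). This position therefore accepts the added chloro without the reading staying at the limit, although the printed floor of the step is too small to count as a real improvement. The 3,4-dichlorophenyl compound can also be set against the 4-fluorophenyl compound, and that comparison, a 1.4-fold higher number from compound 2 to compound 4 (0.14 log units; within the scatter), shows that these two true numbers cannot be told apart.

Going by these compounds, compound 3 has only a limit, so the true size of its step stays unknown, and it shares that limit with one other compound: the limit of > 20000 nM in this assay, at which 2 of the 4 values shown sit.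

On these data alone, whether an amine or a carboxylic acid at this place on the ring would move the number beyond the scatter remains open. All the compounds shown keep the shared core, so they do not show which change, if any, would produce a strong inhibitor in this assay.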